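A few compounds are considered here, and "the series" means these few. Any claim that something is new, unique, unknown or untested is made for them only; others in the source may bear on it.

In a functional assay on Caco-2 cells (Homo sapiens) for inhibition, read by MTT assay, with a stated time of 48 h (on this read-out higher numbers stand for weaker inhibition and lower numbers for stronger inhibition), compound 2 (`COc1cc(/C=N/Nc2nc(-c3cccc(Br)c3)cs2)cc(Br)c1OC`) gives 43400 nM and stands level, within the scatter, with compound 1 (`COc1cc(/C=N/Nc2nc(-c3ccc(Br)cc3)cs2)cc(Br)c1OC`) at 36200 nM on this read-out. For the measured compounds named here, these two differ only by 3-bromophenyl in place of 4-bromophenyl, the one measured step so far (a 1.2-fold higher number from compound 1 to compound 2 (0.08 log units; within the scatter)). Compound 3 (`COc1cc(/C=N/Nc2nc(-c3cccc(Br)c3)cs2)c(Br)c(Br)c1OC`) keeps that 3-bromophenyl and changes another part of compound 2: bromo in place of hydrogen on an aromatic carbon, at a place ortho to a bromo group and para to a methoxy group. Going by the values given here, no measured pair shows what adding a bromo does, and the one measured step only moves a bromo in a different part of the molecule, so it bears on this change only loosely. The small size of that step (a 1.2-fold higher number from compound 1 to compound 2 (0.08 log units; within the scatter)) offers no ground for expecting a large shift, though it cannot rule one out. No step beyond the scatter is therefore expected in this assay for compound 3, and no direction is favoured with confidence. The estimate means an expected step that is small (a 1.1-fold lower number from compound 2 to compound 3 (0.06 log units; within the scatter)) with a wide margin on both sides. Compound 3 is estimated at 38000 nM (range 15000 nM to 90000 nM).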

Compound 3, half-maximal inhibitory concentration: > 100000 nM
Compound 3: only a limit was reported; the forecaster's own chance of this, stated with the estimate: 8%; at least 2.6-fold (0.42 log units) between middle value and limit.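

Adding a bromo at the aromatic carbon ortho to a bromo group and para to a methoxy group is the first change here that moves the read-out beyond the scatter, with an at least 2.3-fold higher number from compound 2 to compound 3 (0.36 log units; beyond the scatter) in this assay. Since higher numbers stand for weaker inhibition on this read-out, this position does not take an extra bromo without a loss, whereas moving a bromo in the other part of the molecule gave only a 1.2-fold higher number from compound 1 to compound 2 (0.08 log units; within the scatter), which lies within the scatter. The result for compound 3 is a limit and not a number, so the step gives only a minimum size: the limit of > 100000 nM in this assay, at which 1 of the 3 values shown sits.

From the compounds shown here alone, what a fluoro, a methyl or an amine at this same place would do remains open, so the loss cannot yet be tied to bromo itself rather than to any added group. Also open is whether the same added bromo would shift the read-out alongside the 4-bromophenyl of compound 1, and the compounds shown give no reason for the shift.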